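A few compounds are considered here, and "the series" means these few. Any claim that something is new, unique, unknown or untested is made for them only; others in the source may bear on it.

Compound 1 `Nc1ncn(Cc2c(Cl)cccc2Cl)c2ncnc1-2` gives 66%
Compound 2 `Nc1ncn(Cc2c(Cl)cncc2Cl)c2ncnc1-2` gives 100%

In an ADME assay on the whole organism (Mus musculus, strain C57BL/6) for pharmacokinetics, read by LC-MS, with a stated time of 24 h, at a dose of 10 mg/kg by the oral route (a lower number here means that a smaller share of the oral dose reaches the circulation, a higher number that a larger share of the oral dose reaches the circulation), compound 2 stands at 100% as the higher of the two, with a gap to compound 1 beyond the scatter. Compound 3 `Cc1ccccc1-c1nc2c(N)ncn(Cc3c(Cl)cncc3Cl)c-2n1` carries 2-methylphenyl in place of hydrogen on an aromatic carbon and otherwise matches compound 2. Within the data shown here, no measured pair shows this change. With compound 2 at 100% the read-out has room only downward, so a fall beyond the scatter is expected. The expected change is a number 40 percentage points lower from compound 2 to compound 3 (beyond the scatter) on this estimate. Compound 3 is estimated at 60% with a range from 30% to 90% as a working figure.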

Compound 3, oral bioavailability: 3%
For compound 3 the middle estimate is 57 percentage points above the measured one, and the stated range ends above it.
By their numbers in this assay, from the lowest: compound 3; then compound 1; then compound 2.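

The aromatic carbon between two ring nitrogen atoms is not a neutral site for oral exposure: 2-methylphenyl in place of hydrogen there gives a number 97 percentage points lower from compound 2 to compound 3 (beyond the scatter) in this assay and takes compound 3 close to the bottom of the scale. The earlier compounds shown here carry only hydrogen at this carbon and so said nothing about it. Nothing at hand bears on the reason for this step.

A single substituent cannot separate an effect of this particular group from one of any substitution at this carbon. From the compounds shown here alone, how a methyl group, an amine or an unsubstituted phenyl ring would read here in this assay stays open.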